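The source may report more compounds than this note shows. Statements on the series, on what has been measured and on what is new or still open speak of the compounds shown alone.

Measured so far: compound 1 `COc1ccccc1C(=O)/C=C/c1ccc(O)c(O)c1` gives 27 nM in an assay on RBL-1 cells for inhibition of Polyunsaturated fatty acid 5-lipoxygenase (Rattus norvegicus); on this read-out higher numbers stand for weaker inhibition and lower numbers for stronger inhibition; compound 2 `COc1ccc(C(=O)/C=C/c2ccc(O)c(O)c2)c(OC)c1` gives 10 nM.

Compound 1 stands with the highest number of the two; the nearest is compound 2, reached by a 2.7-fold lower number from compound 1 to compound 2 (0.43 log units; beyond the scatter) through methoxy in place of hydrogen on an aromatic carbon.

Compound 3 `CCOc1ccc(OC)c(C(=O)/C=C/c2ccc(O)c(O)c2)c1` differs from compound 1 by ethoxy in place of hydrogen on an aromatic carbon. Among the compounds with values here, the one measured step that bears on this, a 2.7-fold lower number from compound 1 to compound 2 (0.43 log units; beyond the scatter), is modest and concerns another alkoxy entering the same ring, though not the same place. A lowering of similar size is therefore expected for compound 3, with a real chance of no step beyond the scatter, so a 1.8-fold lower number from compound 1 to compound 3 (0.26 log units; within the scatter) is the estimate. Compound 3 is expected at 15 nM, between 5 nM and 45 nM.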

Compound 3, half-maximal inhibitory concentration: 3.8 nM
Compound 3: the middle estimate sits 3.9-fold (0.60 log units) above what was measured; the measured number lies below the stated range.
By their numbers in this assay, from the lowest: compound 3; then compound 2; then compound 1.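

Ethoxy on the aromatic carbon para to a methoxy group and meta to a large group is clearly accepted in this assay, giving a 7.1-fold lower number from compound 1 to compound 3 (0.85 log units; beyond the scatter). This exceeds the other alkoxy step, a 2.7-fold lower number from compound 1 to compound 2 (0.43 log units; beyond the scatter), but group and place both differ between these steps, so neither can be credited on its own. No supporting data explain the gain here.

Open, from the compounds shown here alone, is whether methoxy in this same place would match ethoxy. Also open, going by these compounds, is whether a longer chain such as butoxy, or an amine, would hold the lower number.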